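Shifting the Hydroxy Group: Compound 3 to Compound 4

The source may report more compounds than this note shows. Statements on the series, on what has been measured and on what is new or still open speak of the compounds shown alone.

Three measured compounds share one core and differ only in the aryl group on the carbonyl carbon:

Compound 1, `O=C(/C=C/c1ccc2c(c1)B(O)OC2)c1ccc(Br)cc1`, gives 4500 nM in a functional assay on SK-OV-3 cells (Homo sapiens) for cytotoxicity, read by MTT assay, with a stated time of 48 h; a lower number here means a stronger inhibitor, a higher number a weaker inhibitor.
Compound 2, `O=C(/C=C/c1ccc2c(c1)B(O)OC2)c1ccc(I)cc1`, gives 4200 nM.
Compound 3, `O=C(/C=C/c1ccc2c(c1)B(O)OC2)c1ccc(O)cc1`, gives 13000 nM.

Compound 3 stands highest of the three numbers, so it is the weakest inhibitor in this set. Its nearest neighbour is compound 1, with a 2.9-fold higher number from compound 1 to compound 3 (0.46 log units; beyond the scatter); the step of a 3.1-fold higher number from compound 2 to compound 3 (0.49 log units; beyond the scatter) is slightly larger. Between the two halogen compounds, a 1.1-fold lower number from compound 1 to compound 2 (0.03 log units; within the scatter) lies within the scatter, so these two cannot be ordered.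

Compound 4, `O=C(/C=C/c1ccc2c(c1)B(O)OC2)c1ccccc1O`, is not yet measured. It differs from compound 3 in one place: 2-hydroxyphenyl in place of 4-hydroxyphenyl on a carbonyl carbon. Among the measured compounds shown here, none of the measured steps bears on this change. For the measured compounds named here, each of them exchanges a hydroxy group for a halogen on the same aromatic carbon; no measured pair moves a group from one carbon of that ring to another. The two modest steps reaching compound 3 therefore give no direction for compound 4. Going by the values given here, with no relevant precedent, compound 4 is expected to show no step beyond the scatter, no change at the digits printed from compound 3 to compound 4 (within the scatter), with a wide range. The estimate for compound 4 is 13000 nM, expected to fall between 4500 nM and 38000 nM.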

Compound 4, half-maximal inhibitory concentration: 48800 nM
Compound 4: the middle estimate sits 3.8-fold (0.57 log units) below what was measured, and the stated range ends below it.
By their numbers in this assay, from the lowest: compounds 2 and 1 (each within the scatter of the next); then compound 3; then compound 4.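

Moving the hydroxy group alone changes the result in this assay: with the same atoms joined differently, 2-hydroxyphenyl in place of 4-hydroxyphenyl on the carbonyl carbon gives a 3.8-fold higher number from compound 3 to compound 4 (0.57 log units; beyond the scatter) and so shows that the place of the hydroxy group on this ring counts, which the earlier steps, all made on one aromatic carbon, could not show. The 2-hydroxyphenyl group also stands well apart from the two halogen compounds, with an 11-fold higher number from compound 1 to compound 4 (1.04 log units; beyond the scatter) and a 12-fold higher number from compound 2 to compound 4 (1.07 log units; beyond the scatter) as large steps, which makes compound 4 the weakest inhibitor of the four, as all its steps to the others lie beyond the scatter. Nothing available explains why this shift of the hydroxy group raises the number.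

On these data alone, it remains open whether a methoxy group or an amine in place of the hydroxy group of compound 4 would stay near compound 4 or fall back towards compound 3. The compounds shown also leave open whether the 2-hydroxyphenyl step is specific to the hydroxy group or would appear with a bromo or iodo group in that place.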